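Pentyl on the aryl ring of compound 3

The source may report more compounds than this note shows. Statements on the series, on what has been measured and on what is new or still open speak of the compounds shown alone.

Three compounds of the shared core carry numbers in a functional assay on HT-29 cells (Homo sapiens) for antiproliferative activity, read by MTT assay, with a stated time of 96 h; a lower number here means a stronger inhibitor, a higher number a weaker inhibitor. Compound 1 `O=C1NNC(=O)C2(CSC3=C2C(=O)c2ncccc2C3=O)N1` gives 1580 nM; 1600 nM; 1600 nM (3 entries), the repeat entries of compound 1 sitting close together (the several entries of compound 1 in this assay, 1580 nM; 1600 nM; 1600 nM (3 entries)). Compound 2 `O=C1NN(c2ccc([N+](=O)[O-])cc2)C(=O)C2(CSC3=C2C(=O)c2ncccc2C3=O)N1` gives 1010 nM. Compound 3 `O=C1C2=C(C(=O)c3ncccc31)C1(CS2)NC(=O)N(c2ccccc2)C1=O` gives 2 nM, the lowest number of the two single values, with compound 2 a distant nearest neighbour; the gap between them is well beyond the scatter. Compound 4 `CCCCCc1ccc(N2C(=O)NC3(CSC4=C3C(=O)c3ncccc3C4=O)C2=O)cc1` is not yet measured. It differs from compound 3 by pentyl in place of hydrogen on an aromatic carbon. Among the measured compounds shown here, no measured step reports this kind of change in this assay, so the expected step from compound 3 to compound 4 is modest, likely within or near the scatter, direction uncertain. Compound 4 is estimated at 5 nM, range 1 nM to 30 nM, an expected step of a 2.5-fold higher number from compound 3 to compound 4 (0.40 log units; beyond the scatter).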

Compound 4, half-maximal inhibitory concentration: 250 nM
Beside the measured number, compound 4's estimate is 50-fold (1.70 log units) below it; the whole stated range lies below it.
By their numbers in this assay, from the lowest: compound 3; then compound 4; then compound 2.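

In this assay, the aryl ring of the shared core proves sensitive to substitution: pentyl on an aromatic carbon, para to a large group, gives a 130-fold higher number from compound 3 to compound 4 (2.10 log units; beyond the scatter). Among the compounds shown here, the earlier compounds offered no step between neighbours, so this is the only reading of this position. A shift of this size stands well clear of the agreement among repeats in this assay: the several entries of compound 1 in this assay, 1580 nM; 1600 nM; 1600 nM (3 entries)

Going by these compounds, whether the change belongs to pentyl itself or to any group at this place stays open. A methyl, a methoxy or an amine there would separate the two.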